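The source may report more compounds than this note shows. Statements on the series, on what has been measured and on what is new or still open speak of the compounds shown alone.

In an assay on membranes from brain for displacement of a labelled ligand from adenosine receptor A1 (Rattus norvegicus), read by scintillation counting, with a stated time of 90 min (on this read-out higher numbers stand for weaker inhibition and lower numbers for stronger inhibition), compound 1, `O=C(CCc1ccccc1)Nc1nc2ccccc2c(=O)s1`, gives 422 nM. This is the higher of the two numbers recorded, the other belonging to compound 2, `COc1cccc(/C=C/C(=O)Nc2nc3ccccc3c(=O)s2)c1`, which in this assay gives 205 nM; the gap between the two values lies beyond the usual scatter. Compound 3, `O=C(CCc1ccccc1F)Nc1nc2ccccc2c(=O)s1`, has not been measured. It differs from compound 1 in one place: fluoro in place of hydrogen on an aromatic carbon. Within the data shown here, no measured pair in this small set shows the effect of such a change, so there is nothing to lean on beyond the structures themselves, and a shift within the scatter, in either direction, is the most likely outcome. The expected step of a 1.2-fold lower number from compound 1 to compound 3 (0.08 log units; within the scatter) is therefore small. Compound 3 is expected to give 350 nM in this assay, with a range from 150 nM to 900 nM.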

Compound 3, inhibition constant: > 10000 nM
Compound 3 was reported as a limit; the forecaster's own chance of this, stated with the estimate: 3%; at least 28-fold (1.45 log units) between middle value and limit.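

Fluoro in place of hydrogen on an aromatic carbon, ortho to a large group, proves to be far from a silent change on this phenyl ring: in this assay it gives an at least 23-fold higher number from compound 1 to compound 3 (1.37 log units; beyond the scatter). The result for compound 3 is a limit of the assay, not a number: the limit of > 10000 nM in this assay, at which 1 of the 3 values shown sits. The earlier compounds shown here offered no step in one place, and this first such step shows that a single fluorine atom at this position, with no ring or charge entering, can move the read-out well beyond the scatter.

The compounds shown leave open whether this step belongs to fluoro itself or to the place it occupies, as chloro or methyl at this position, or fluoro on another carbon of the ring, would tell. They also leave open whether the same change on the phenyl ring of compound 2 would give a step of similar size.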